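Shortening the polyamine tail on the shared core

The source may report more compounds than this note shows. Statements on the series, on what has been measured and on what is new or still open speak of the compounds shown alone.

Measured so far, in a functional assay on HT-29 cells (Homo sapiens) for antiproliferative activity, read by MTT assay, with a stated time of 48 h; a lower number here means a stronger inhibitor, a higher number a weaker inhibitor:
compound 1 `COc1ccc(/C=C/C(=O)c2cc(OC)c(OC)c(OC)c2)cc1OCCCC(=O)NCCCNCCCCNCCN`: > 100000 nM
compound 2 `COc1cc(C(=O)/C=C/c2ccc(OCCCC(=O)NCCCCN(CCCN)CCCCNCCCN)cc2)cc(OC)c1OC`: 91700 nM

The figure for compound 1 is a limit of the assay, not a number. Compound 1 therefore stands at the weak end of what is shown, with the limit of > 100000 nM in this assay, at which 1 of the 2 values shown sits, as the only evidence of where it sits. Compound 2 gives a measured number that lies close to that limit.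

Compound 3 `COc1ccc(/C=C/C(=O)c2cc(OC)c(OC)c(OC)c2)cc1OCCCC(=O)NCCCCNCCCN` differs from compound 1 by ((3-aminopropyl)amino)methyl in place of (4-((2-aminoethyl)amino)butyl)amino on a saturated chain carbon, three bonds along the chain from an amide-type nitrogen. The tail that leaves carries one more nitrogen than the tail that enters, so compound 3 keeps fewer of the basic centres of compound 1. Among the measured compounds shown here, no measured pair here separates the two tails, so nothing shows how far this trimming moves the result in this assay; the expectation is a step of no more than the usual scatter, if any, with compound 3 remaining a very weak inhibitor.

Compound 3 is expected to give 100000 nM, within a range of 40000 nM to 250000 nM. The step of a number no higher from compound 1 to compound 3 (the limit leaves the size open) is the expected change, with a real chance that only a limit is reported again.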

Compound 3, half-maximal inhibitory concentration in the HT-29 assay: > 100000 nM
Compound 3: a limit, no number; the forecaster's own chance of this, stated with the estimate: 55%; the middle value lies on the limit itself.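

Compound 1 and compound 3 both end at a limit in the HT-29 assay, so no step between them can be read: the limit of > 100000 nM in the HT-29 assay, at which 2 of the 3 values shown sit.

In a physicochemical assay for lipophilicity, read by spectrophotometry, measured as octanol-water partition, tested at 300 uM (a higher number here means a more lipophilic compound, a lower number a more polar compound), compound 1 gives -1.57 and compound 3 gives -1.28, which is a number 0.29 log units higher from compound 1 to compound 3 (within the scatter).

The compounds shown leave open how far either tail on the shared core lies from that limit in the HT-29 assay.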